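Moving the chlorine on the benzyl ether of compound 3

The source may report more compounds than this note shows. Statements on the series, on what has been measured and on what is new or still open speak of the compounds shown alone.

The account follows a small series of ureas that share one core. In an ADME assay on cells (Astrocyte, Homo sapiens) for cytotoxicity, read by WST assay, with a stated time of 72 h (a lower number here means a stronger inhibitor, a higher number a weaker inhibitor), compound 1 `O=C(Nc1cccc(F)c1)Nc1cc2ncncc2cc1OCc1cccc(Cl)c1` reports only a limit, > 10000 nM, not a number. Compound 2 `O=C(Nc1cccc(Cl)c1)Nc1cc2ncncc2cc1OCc1ccccc1` gives 7400 nM in this assay. Compound 3 `O=C(Nc1cccc(Cl)c1)Nc1cc2ncncc2cc1OCc1ccccc1Cl` likewise stops at a limit, > 10000 nM, in this assay. Compound 3 therefore stands among the two of three values that sit at the limit (the limit of > 10000 nM in this assay, at which 2 of the 3 values shown sit), so its position is known only as a bound. Within the data shown here, the one measured step, an at least 1.3-fold higher number from compound 2 to compound 3 (0.13 log units; that floor lies within the scatter), arises from a chloro in place of hydrogen on an aromatic carbon, and its floor lies within the scatter.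

Compound 4 `O=C(Nc1cccc(Cl)c1)Nc1cc2ncncc2cc1OCc1cccc(Cl)c1` is the next compound and differs from compound 3 by 3-chlorophenyl in place of 2-chlorophenyl on a saturated chain carbon bound to an oxygen on an aromatic ring. Among the measured compounds shown here, no measured step covers this change directly, and compound 1, which carries the same 3-chlorobenzyl ether, reported only a limit. Since compound 3 is itself a limit, there is no basis for expecting a step beyond the scatter in this assay, and compound 4 is expected to remain at or past the limit, with an expected step that the limit leaves unreadable from compound 3 to compound 4. The estimate for compound 4 is 15000 nM, between 6000 nM and 50000 nM.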

Compound 4, half-maximal inhibitory concentration: > 10000 nM
Compound 4 gave a limit, no number; the forecaster's own chance of this, stated with the estimate: 70%; the middle value lies beyond the limit too.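

Compound 4 shows that with the chloro on a 3-chlorobenzyl ether, as with the 2-chlorobenzyl ether of compound 3, this assay still ends in a limit and not a number. Among these compounds, the only step that can be read is an at least 1.3-fold higher number from compound 2 to compound 4 (0.13 log units; that floor lies within the scatter), for a chloro in place of hydrogen on an aromatic carbon, and it shows no more than the earlier step to the 2-chlorobenzyl ether did. The steps to compound 4 from compound 3 and from compound 1 cannot be read, since both ends of each are limits, so moving the chlorine has no measurable size here, and the series now sits largely at one bound: the limit of > 10000 nM in this assay, at which 3 of the 4 values shown sit.

On these data alone, whether compound 3 and compound 4 differ at all in this assay, and how far past the limit either lies, stays open. Also open, as far as these compounds go, is what an amine or a carboxylic acid in place of the chloro on the benzyl ether would give in this assay.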